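From Carbonyl to Sulfonyl on the Ring Nitrogen

This account rests on a few compounds, and the source may have more. Where it says the series, first, only, none or still open, it means among the compounds named here.

In a functional assay on NCI-H1975 cells (Homo sapiens) for inhibition, read by sulforhodamine B assay, tested at 10 uM (on this read-out lower numbers stand for less inhibition and higher numbers for more inhibition at the one concentration tested (going by the name of the read-out)), three compounds have been measured so far. Compound 1 `CN1CCN(c2ccc(C3=NN(S(=O)(=O)c4ccc(Br)cc4)C(c4ccc(N(C)C)cc4)C3)cc2)CC1` gives 70.8%, compound 2 `CN(C)c1ccc(C2CC(c3ccc(-n4cncn4)cc3)=NN2C(=O)c2ccc(F)cc2)cc1` gives -1.1%, and compound 3 `CN(C)c1ccc(C2CC(c3ccc(-n4cncn4)cc3)=NN2C(=O)c2ccc(C(F)(F)F)cc2)cc1` gives 11.5%. Compound 3 therefore stands second highest of the three numbers: the step of a number 12.6 percentage points higher from compound 2 to compound 3 (beyond the scatter) is beyond the scatter but modest, while compound 1 lies far above it.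

Compound 4 `CN(C)c1ccc(C2CC(c3ccc(-n4cncn4)cc3)=NN2S(=O)(=O)c2ccc(Br)cc2)cc1` has not yet been measured. It differs from compound 3 in one place: (4-bromophenyl)sulfonyl in place of (4-(trifluoromethyl)phenyl)carbonyl on an amine nitrogen in a ring. Going by the values given here, the entering (4-bromophenyl)sulfonyl is the same group that compound 1 carries on an amine nitrogen in a ring, but compound 1 differs from compound 4 elsewhere as well, so no measured step covers exactly this exchange. Among the compounds with values here, the only step known, a number 12.6 percentage points higher from compound 2 to compound 3 (beyond the scatter), concerns a change on an aromatic carbon rather than on the ring nitrogen, so it bears on the new step only loosely. Within the data shown here, compound 1 reached 70.8% and compound 3 reached 11.5%; these two numbers show only that a compound with this sulfonyl group can score high in this assay. An increase is therefore expected, though with wide uncertainty, and the step of a number 33.5 percentage points higher from compound 3 to compound 4 (beyond the scatter) is an estimate. Compound 4 is expected to give 45%, with a range from 15% to 75%.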

Compound 4, a percentage reported as inhibition, at one concentration (the size of the read-out at that concentration, not a potency): -0.6%
Compound 4: middle estimate off by 45.6 percentage points, on the high side, outside the stated range (below it).
By their numbers in this assay, from the lowest: compounds 2 and 4 (each within the scatter of the next); then compound 3; then compound 1.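

In this assay, the change on the amine nitrogen in the ring does not by itself lift the number: (4-bromophenyl)sulfonyl in place of (4-(trifluoromethyl)phenyl)carbonyl gives a number 12.1 percentage points lower from compound 3 to compound 4 (beyond the scatter), and in place of (4-fluorophenyl)carbonyl it gives a number 0.5 percentage points higher from compound 2 to compound 4 (within the scatter). With the (4-bromophenyl)sulfonyl group held fixed, the other position makes a far bigger difference, since 1H-1,2,4-triazol-1-yl in place of 4-methylpiperazin-1-yl on an aromatic carbon gives a number 71.4 percentage points lower from compound 1 to compound 4 (beyond the scatter), so the high number of compound 1 cannot be credited to the sulfonyl group alone. No supporting measurement is available to explain the size of any of these steps.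

Going by these compounds, it remains open whether 4-methylpiperazin-1-yl on that aromatic carbon would also give a high number with a carbonyl group on the ring nitrogen, or only with the sulfonyl group. On these data alone, it is also open whether another ring amine at that carbon, such as morpholine or piperidine, would behave like 4-methylpiperazin-1-yl or like 1H-1,2,4-triazol-1-yl.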